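Chloro for ethyl on the benzyl ring of compound 1

This account rests on a few compounds, and the source may have more. Where it says the series, first, only, none or still open, it means among the compounds named here.

Measured so far in an assay on CHO cells for displacement of a labelled ligand from prostaglandin E2 receptor EP4 subtype (Mus musculus), read by scintillation counting, with a stated time of 60 min; a lower number here means a stronger inhibitor, a higher number a weaker inhibitor:
compound 1, `CCc1cccc(C[C@H](O)/C=C/[C@H]2COC(=O)N2CCSCCCC(=O)O)c1` — 7.9 nM
compound 2, `CCCc1cccc(C[C@H](O)/C=C/[C@H]2CCC(=S)N2CCCCCCC(=O)O)c1` — 0.4 nM

Compound 1 gives 7.9 nM in this assay, the higher of the two numbers recorded, and compound 2 gives 0.4 nM, a gap that lies beyond the usual scatter. The two compounds differ in several places at once, so the values say only where each stands, not which change accounts for the gap.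

Compound 3, `O=C(O)CCCSCCN1C(=O)OC[C@@H]1/C=C/[C@@H](O)Cc1cccc(Cl)c1`, is not yet measured. Relative to compound 1 the change is chloro in place of ethyl on an aromatic carbon; the core and the acid-bearing chain are kept. Among the measured compounds shown here, no pair of measured compounds differing in one place is available, so the size of this kind of exchange in this assay has no precedent here. Swapping one small aromatic substituent for another of comparable size is expected to move the number little, and the step from compound 1 to compound 3 is estimated at a 1.3-fold higher number from compound 1 to compound 3 (0.10 log units; within the scatter), within the scatter in either direction. Compound 3 is therefore expected to give about 10 nM, with a range from 3 nM to 35 nM.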

Compound 3, inhibition constant: 1.5 nM
Beside the measured number, compound 3's estimate is 6.7-fold (0.82 log units) above it; measured number outside the range, below it.
By their numbers in this assay, from the lowest: compound 2; then compound 3; then compound 1.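

In this assay, among the compounds shown here, chloro in place of ethyl on the aromatic carbon gives a 5.3-fold lower number from compound 1 to compound 3 (0.72 log units; beyond the scatter), the only single-place step so far. This shows that the number responds to which substituent this place carries: the core and the acid-bearing chain are kept, and the exchange of two carbon atoms for one chlorine atom adds no ring, hydrogen-bond donor, hydrogen-bond acceptor or net charge, yet the step lies beyond the scatter. No evidence at hand bears on the origin of this step.

One exchange cannot show whether the lower number is particular to chloro or would extend to other groups at this place, such as fluoro, bromo, methoxy or trifluoromethyl. Also open, from the compounds shown here alone, is whether chloro in place of ethyl would give a step of similar size on the core and chain of compound 2, which differs from compound 3 in several places and so cannot be compared with it directly.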